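Replacing the 4-methoxyphenyl group of compound 2

The source may hold more compounds than are shown below. What is called first, only, known or untested is meant among the compounds shown, and "the series" means these compounds.

Measured in a functional assay on HeLa cells (Homo sapiens) for inhibition, read by CCK-8 assay, with a stated time of 72 h, tested at 8 uM (on this read-out lower numbers stand for less inhibition of growth and higher numbers for more inhibition of growth at the one concentration tested), so far:
- compound 1 `Nc1ccccc1NC(=O)/C=C/c1ccc(CSc2ccc(Cl)cc2)cc1` gives 17.3%
- compound 2 `COc1ccc(SCc2ccc(C(=O)Nc3ccccc3N)cc2)cc1` gives 79.7%
- compound 3 `COc1ccc(SCc2ccc(C(=O)Nc3ccccc3N)cc2)cc1OC` gives 79.9%

Compound 2, at 79.7%, lies level with compound 3 within the scatter, while compound 1 lies far lower, beyond the scatter. Going by the values given here, compound 1 differs from compound 2 in more than one place, so it offers no direct step. Compound 4 `Cc1cc(C)cc(SCc2ccc(C(=O)Nc3ccccc3N)cc2)c1` has not yet been measured and changes one group of compound 2: 3,5-dimethylphenyl in place of 4-methoxyphenyl on a sulfur, with 3,5-dimethylphenyl in place of 4-methoxyphenyl on a sulfur. Among the compounds with values here, only one measured step bears on this change: a number 0.2 percentage points higher from compound 2 to compound 3 (within the scatter), with methoxy in place of hydrogen on an aromatic carbon. Within the data shown here, no measured compound carries the 3,5-dimethylphenyl group, so that evidence is indirect. The expected step is therefore small, a number 3.7 percentage points lower from compound 2 to compound 4 (within the scatter), with no firm direction. In this assay compound 4 is estimated at 76%, with a range of 55% to 90% expected.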

Compound 4, percent growth inhibition at one concentration: 78.9%
Estimate against measurement, compound 4: 2.9 percentage points below; measured number inside the range.
By their numbers in this assay, from the lowest: compound 1; then compounds 4, 2 and 3 (each within the scatter of the next).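

In this assay, replacing the 4-methoxyphenyl group on the sulfur with 3,5-dimethylphenyl gives a number 0.8 percentage points lower from compound 2 to compound 4 (within the scatter). The earlier step, a number 0.2 percentage points higher from compound 2 to compound 3 (within the scatter), only added a methoxy group, whereas this change removes the group's one oxygen and its one hydrogen-bond acceptor while keeping the heavy-atom count, and the percent growth inhibition stays level within the scatter. Nothing measured here explains why this position tolerates the exchange.

As far as these compounds go, it remains open whether an amine or a carboxylic acid on this aromatic ring, or a longer chain in place of the ring, would keep inhibition at this level. Compound 1 differs from compound 2 in more than one place, so its much lower number cannot be assigned to any single change.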